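The source may report more compounds than this note shows. Statements on the series, on what has been measured and on what is new or still open speak of the compounds shown alone.

For the measured compounds named here, compound 2, `O=C1N([C@H](CO)c2cccc(Cl)c2)Cc2cc(-c3nc(NC4CCOCC4)ncc3Cl)cn21`, is the only member of this small set with a number in a functional assay on COLO 205 cells (Homo sapiens) for antiproliferative activity, read by luminescence, with a stated time of 72 h; on this read-out lower numbers stand for stronger inhibition and higher numbers for weaker inhibition: in this assay compound 2 gives 104 nM. The two other measured compounds offer no number to compare against. Compound 1, `Cc1cnc(Nc2ccnn2C)nc1-c1cc2n(c1)C(=O)N([C@H](C)c1cccc(Cl)c1)C2`, is reported in this assay as "not active" (no number reported), and compound 3, `CC(C)Nc1cc(-c2cc3n(c2)C(=O)N([C@H](CO)c2cccc(Cl)c2)C3)c(Cl)cn1`, is likewise reported as "not active" (no number reported). So compound 2 stands alone as the reference point, with no measured neighbours that differ from it in a single place.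

Compound 4, `Cn1nccc1Nc1ncc(Cl)c(-c2cc3n(c2)C(=O)N([C@H](CO)c2cccc(Cl)c2)C3)n1`, has not yet been measured. It differs from compound 2 in one place: 1-methyl-1H-pyrazol-5-yl in place of oxan-4-yl on a nitrogen on an aromatic ring. The rest of the molecule, including the hydroxymethyl-bearing side chain and the chloro substituent on the shared core, is kept.

Going by the values given here, with no step between measured compounds to lean on, the size of this change is uncertain. Compound 1 carries the same 1-methyl-1H-pyrazol-5-yl amino group and is reported as inactive, but it differs from compound 4 in other places too, so it cannot settle the question. A modest weakening beyond the scatter is expected for compound 4, with the step from compound 2 to compound 4 estimated at a 2.7-fold higher number from compound 2 to compound 4 (0.43 log units; beyond the scatter). In this assay compound 4 is therefore expected to give about 280 nM, within a range of 70 nM to 1500 nM.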

Compound 4, half-maximal inhibitory concentration: 31.9 nM
Beside the measured number, compound 4's estimate is 8.8-fold (0.94 log units) above it, outside the stated range (below it).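

In this assay, the step at this position reads a 3.3-fold lower number from compound 2 to compound 4 (0.51 log units; beyond the scatter), a modest change that lies beyond the scatter. This shows that the group on this nitrogen on an aromatic ring can influence the antiproliferative result, and that 1-methyl-1H-pyrazol-5-yl in place of oxan-4-yl gives stronger inhibition with the rest of the molecule held constant. The two groups have the same heavy-atom count, so the gain comes with a change in the kind of ring rather than in the number of heavy atoms, but no measurement here explains why the number falls.

A single step cannot show which feature of the entering group matters: its aromatic ring, its five-membered shape, its two ring nitrogens or its methyl group. A phenyl ring, a cyclopentyl ring or a pyrazole without the methyl group on this nitrogen would help to separate these features, and the compounds shown leave open how any of them would compare.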